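Widening the furan to a benzofuran on a nucleoside core

This account rests on a few compounds, and the source may have more. Where it says the series, first, only, none or still open, it means among the compounds named here.

Compound 1 `O=c1[nH]cnc2c1c(-c1ccoc1)cn2[C@@H]1O[C@H](CO)[C@@H](O)[C@H]1O` is the reference point here, and in a functional assay on HepG2 cells (Homo sapiens) for antiproliferative activity, read by XTT assay, with a stated time of 72 h (a lower number here means a stronger inhibitor, a higher number a weaker inhibitor), compound 1 gives 12100 nM, the only plain number shown. Compound 2 `Nc1nc2c(c(-c3ccoc3)cn2[C@@H]2O[C@H](CO)[C@@H](O)[C@H]2O)c(=O)[nH]1` reaches only a limit of this assay, > 20000 nM. The change from compound 1 to compound 2 is an amino in place of hydrogen on an aromatic carbon, and its step of an at least 1.6-fold higher number from compound 1 to compound 2 (0.21 log units; that floor lies within the scatter) rests on (the limit of > 20000 nM in this assay, at which 1 of the 2 values shown sits). Compound 3 `O=c1[nH]cnc2c1c(-c1cc3ccccc3o1)cn2[C@@H]1O[C@H](CO)[C@@H](O)[C@H]1O` differs from compound 1 in another place: 1-benzofuran-2-yl in place of furan-3-yl on an aromatic carbon. For the measured compounds named here, no measured step follows this kind of change, so the amino step of compound 2 offers no guide, and the expectation can rest only on the value of compound 1 with wide uncertainty. The expected step is a 1.3-fold lower number from compound 1 to compound 3 (0.13 log units; within the scatter), a change that may well stay within the scatter. In this assay compound 3 is estimated at 9000 nM, within a range from 2500 nM to 20000 nM.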

Compound 3, half-maximal inhibitory concentration: > 20000 nM
Compound 3 ended at the assay's limit; the forecaster's own chance of this, stated with the estimate: 30%; middle value at least 2.2-fold (0.34 log units) away from the limit.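

In this assay, putting 1-benzofuran-2-yl in place of furan-3-yl on the shared core gives an at least 1.6-fold higher number from compound 1 to compound 3 (0.21 log units; that floor lies within the scatter). For the compounds shown here, this is the first view of a change at this position, since the earlier step lay elsewhere on the core, and the added six-membered aromatic ring brings no visible gain, although the floor of the step does not establish a real loss. The step can be read only as a floor, as compound 3 gives a limit of the assay and not a number: the limit of > 20000 nM in this assay, at which 2 of the 3 values shown sit.

Going by these compounds, how far the true value of compound 3 lies past that limit stays unknown. Also open, on these data alone, is whether another group at this position, such as a phenyl or a pyridine ring carrying an amine, would give a lower number than compound 1.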